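Chloro on the sulfonyl ring: aortic potency in a small urea series

A few compounds are considered here, and "the series" means these few. Any claim that something is new, unique, unknown or untested is made for them only; others in the source may bear on it.

Measured so far:
compound 1, `COc1ccc(Cl)cc1C(C)NC(=O)N(C)S(=O)(=O)c1ccc(Cl)cc1`, 20000 nM
compound 2, `COc1ccc(Cl)cc1C(C)NC(=O)N(C)S(=O)(=O)c1ccccc1`, 7200 nM
compound 3, `CC(NC(=O)N(C)S(=O)(=O)c1ccccc1)c1ccccc1OCc1ccccc1`, 21700 nM

All three were run in a functional assay on thoracic aorta (Rattus norvegicus, strain Wistar), with a stated time of 15 min; on this read-out higher numbers stand for an effect only at larger amounts of compound and lower numbers for an effect already at smaller amounts. Compound 2 gives 7200 nM. Compound 1 differs from it by chloro in place of hydrogen on an aromatic carbon, and the step of a 2.8-fold higher number from compound 2 to compound 1 (0.44 log units; beyond the scatter) is beyond the scatter, so this change made the number go up on this core. Compound 3 gives 21700 nM in this assay; its core differs from that of compound 2 in a way that is not broken down here. Compound 3 and compound 1 lie within the scatter of each other, while compound 2 sits below both.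

Compound 4, `CC(NC(=O)N(C)S(=O)(=O)c1ccc(Cl)cc1)c1ccccc1OCc1ccccc1`, is not yet measured. It differs from compound 3 by chloro in place of hydrogen on an aromatic carbon. Relative to the change from compound 2 to compound 1, the place line is the same word for word, so this is the same change, now applied to the core of compound 3. Among the compounds with values here, the one earlier instance a 2.8-fold higher number from compound 2 to compound 1 (0.44 log units; beyond the scatter) is the only guide, and whether it carries over to a different core is open.

On that basis the step in this assay is expected to be a 2.3-fold higher number from compound 3 to compound 4 (0.36 log units; beyond the scatter), resting on the earlier step from compound 2 to compound 1 and on the value of compound 3 21700 nM. For compound 4 in this assay the estimate is 50000 nM, with a range from 18000 nM to 140000 nM, and a fair chance that a number this high is reported only as a limit.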

Compound 4, half-maximal effective concentration: 38400 nM
Compound 4: middle estimate off by 1.3-fold (0.11 log units), on the high side, and the stated range covers the measured number.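

In this assay, chloro in place of hydrogen on the phenylsulfonyl ring of the core of compound 3 gives a 1.8-fold higher number from compound 3 to compound 4 (0.25 log units; within the scatter), so on this core the step alone cannot be told apart from repeat measurements. Set beside the earlier step on the core of compound 2, the size of the change does not differ measurably between the two cores: the same change on two cores in this assay, a 2.8-fold higher number (0.44 log units; beyond the scatter) from compound 2 to compound 1 and a 1.8-fold higher number (0.25 log units; within the scatter) from compound 3 to compound 4, 1.6-fold (0.20 log units) apart, within the scatter of two such steps

Within the data shown here, this is consistent with phenyl to 4-chlorophenyl carrying over between these two cores, but it does not establish a shared, reliable effect, since only the step on the core of compound 2 lies beyond the scatter and the comparison rests on a single pair per core.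

Still open, from the compounds shown here alone, is how fluoro, methyl, methoxy or a carboxylic acid on the same aromatic carbon would compare with chloro on either core. Also open, going by these compounds, is whether the step would hold on a third core, for example one carrying an amine on the other aromatic ring, or with a longer chain in place of the methyl on the urea nitrogen.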